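Metabolic stability notes: compound 1 to compound 4

This account rests on a few compounds, and the source may have more. Where it says the series, first, only, none or still open, it means among the compounds named here.

Compound 1 `NCCCCN(C[C@H]1Cc2ncccc2CN1)[C@H]1CCCc2cccnc21` sits second highest of the three numbers in an ADME assay on microsomes from liver (Rattus norvegicus) for metabolic stability, using NADPH, with a stated time of 10 min (on this read-out higher numbers stand for a more stable compound and lower numbers for a less stable compound), where compound 1 gives 64%. Compound 3 `NCCCCN(C[C@@H]1Cc2nccnc2CN1)[C@H]1CCCc2cccnc21` is nearest, and in this assay compound 3 gives 67%, a gap within the scatter. Compound 2 `NCCCCN(C[C@@H]1Cc2ncccc2CN1)[C@H]1CCCc2cccnc21` is furthest; in this assay compound 2 gives 55%. For the measured compounds named here, the one measured step, a number 9 percentage points lower from compound 1 to compound 2 (within the scatter), is within the scatter and rests only on (the fact that compounds 1 and 2 differ only in the configuration as drawn).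

Compound 4 `c1cnc2c(c1)CN[C@@H](CN(CCCCN(C1COC1)C1COC1)[C@H]1CCCc3cccnc31)C2` differs from compound 1 by a group of 9 heavy atoms (6 carbon, 1 nitrogen, 2 oxygen; 2 four-membered non-aromatic rings with 1 hetero atom each) in place of one nitrogen atom, on a saturated chain carbon, four bonds along the chain from an amine nitrogen. Going by the values given here, no measured step changes a group at that place: the step from compound 1 to compound 2 alters configuration only, so it gives no guide to replacing the amino group. With nothing in the measured series bearing on this change, the working expectation for compound 4 is a value near compound 1, with no step beyond the scatter foreseen in either direction, though the range must stay wide. Compound 4 is estimated at 60% (range 35% to 85%), which would mean an expected step of a number 4 percentage points lower from compound 1 to compound 4 (within the scatter).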

Compound 4, percent of the compound remaining: 72%
For compound 4 the middle estimate is 12 percentage points below the measured one; the range from low to high includes it.
By their numbers in this assay, from the lowest: compounds 2, 1, 3 and 4 (each within the scatter of the next, the first and the last beyond it).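

The place on a saturated chain carbon, four bonds along the chain from an amine nitrogen, accepts a much larger group than the amino group: in this assay, exchanging it for the group of 9 heavy atoms with 2 four-membered non-aromatic rings with 1 hetero atom each gives a number 8 percentage points higher from compound 1 to compound 4 (within the scatter), a result the configuration-only step could not show. The read-out therefore stays within the scatter even though the entering group has 0 hydrogen-bond donors where the amino group has 1. Nothing given here explains why the read-out holds after this change.

The compounds shown leave open whether a dimethylamino group or a carboxylic acid at this place would give a similar read-out, and whether a longer chain carrying the same group would do so. They also leave open whether this exchange would behave alike on the core of compound 2 or compound 3.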